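The compounds below may be only part of what the source reports. "The series", "measured", "known", "first", "only" and "open" are said of these compounds alone.

Measured in a functional assay on NCI-H520 cells (Homo sapiens) for cytotoxicity; a higher number here means a weaker inhibitor of growth, a lower number a stronger inhibitor of growth:
Compound 1 `COc1ccc(C2=C(c3cc(OC)c(OC)c(OC)c3)CC3CCCN3C2=O)cc1O`: > 100000 nM
Compound 2 `COc1ccc(C2=C(c3ccc(SC)cc3)CC3CCCN3C2=O)cc1O`: 6000 nM

Compound 1 gives > 100000 nM, which is a limit of the assay and not a number. For the measured compounds named here, compound 2, at 6000 nM, holds the only actual number in the set. Compound 3 `COc1ccc(C2=C(c3ccc(SC)cc3)CC3CCCN3C2=O)cc1OC(=O)CNC(=O)OC(C)(C)C` is compound 2 with one change, (((tert-butoxycarbonyl)amino)methyl)carbonyl in place of hydrogen on an oxygen on an aromatic ring. Going by the values given here, no measured step covers this change, so the expectation is only tentative. A moderate weakening is expected, with the estimated step being a 1.7-fold higher number from compound 2 to compound 3 (0.22 log units; within the scatter). For compound 3 the estimated value in this assay is 10000 nM, with an expected range from 2500 nM to 50000 nM.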

Compound 3, concentration for 50% growth inhibition: 7000 nM
Estimate against measurement, compound 3: 1.4-fold (0.15 log units) above, and the stated range covers the measured number.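

In this assay, placing (((tert-butoxycarbonyl)amino)methyl)carbonyl in place of hydrogen on an oxygen on an aromatic ring gives a 1.2-fold higher number from compound 2 to compound 3 (0.07 log units; within the scatter). The hydrogen on this oxygen can therefore be replaced by this much larger group with no change beyond the scatter. Compound 1 adds no second comparison, as its entry is a limit of the assay and not a number: the limit of > 100000 nM in this assay, at which 1 of the 3 values shown sits.

On these data alone, whether this holds for other groups on this oxygen remains open. A small methyl group, or an acyl chain ending in a free amine or a carboxylic acid, could read differently.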